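Replacing the 4-chlorobenzyl group of compound 2

The source may report more compounds than this note shows. Statements on the series, on what has been measured and on what is new or still open speak of the compounds shown alone.

In an ADME assay on microsomes from liver (Mus musculus) for metabolic stability, with a stated time of 10 min, tested at 0.5 uM (a lower number here means that less of the compound is left, a higher number that more of the compound is left), compound 2 `C[C@@H](NCc1ccc(Cl)cc1)[C@H]1CC[C@@H](c2ccnc3ccc(F)cc32)CC1` gives 2%. Within the data shown here, compound 3 `C[C@@H](c1nc2ccc(Cl)cc2[nH]1)[C@H]1CC[C@@H](c2ccnc3ccc(F)cc32)CC1` gives 12%, the only other number available, and the two values lie within the usual scatter of each other. Compound 1 `C[C@@H](C(=O)NC1CCCCC1)[C@H]1CC[C@@H](c2ccnc3ccc(F)cc32)CC1` gives < 1%, which is a limit of the assay and not a number.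

Compound 4 `C[C@@H](NC(=O)Nc1ccc(Cl)cc1)[C@H]1CC[C@@H](c2ccnc3ccc(F)cc32)CC1` has not yet been measured. It shares the core of compound 2 but carries (4-chlorophenyl)carbamoyl in place of 4-chlorobenzyl on an amine nitrogen. Among the measured compounds shown here, the one measured step bearing on this change also exchanges a carbamoyl-containing group for one containing 4-chlorobenzyl, and it shows a number at least 1 percentage points higher from compound 1 to compound 2 (that floor lies within the scatter). On these data alone, that step starts from the limit of < 1% in this assay, at which 1 of the 3 values shown sits, so its true size remains open. The step from compound 1 to compound 2 offers no support for expecting a large move in either direction from compound 2, which stands at 2%, so no step beyond the scatter is expected in this assay. The expected change is a number 3 percentage points higher from compound 2 to compound 4 (within the scatter), a small rise that would stay within the scatter. For compound 4 the estimated value is 5%, with an expected range from 1% to 16%.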

Compound 4, percent of the compound remaining: 14%
Compound 4: middle estimate off by 9 percentage points, on the low side, within the range that was stated.
By their numbers in this assay, from the lowest: compounds 2, 3 and 4 (each within the scatter of the next, the first and the last beyond it). At a limit, below all of these: compound 1.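

In this assay, (4-chlorophenyl)carbamoyl in place of 4-chlorobenzyl on an amine nitrogen gives a number 12 percentage points higher from compound 2 to compound 4 (beyond the scatter), the only step shown that lies beyond the scatter. This marks the amine nitrogen as a place where exchanging the group moves the read-out by more than repeated measurements would, although compound 4 still gives only 14%. The one earlier step, which starts from compound 1, could not show this, since its true size stays open: the limit of < 1% in this assay, at which 1 of the 4 values shown sits.

The compounds shown leave open which part of the entering group goes with the rise, and an acetyl group or a cyclohexylcarbamoyl group on the same amine nitrogen would separate the carbonyl and the amide hydrogen from the chlorinated aromatic ring. Also open, on these data alone, is whether a sulfonamide at this nitrogen would move the number further, and whether the rise would hold for the same exchange on any core other than the shared one.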